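The source may hold more compounds than are shown below. What is called first, only, known or untested is meant among the compounds shown, and "the series" means these compounds.

Working notes on the series.

Three compounds in the set carry a measurement in a functional assay on HepG2 cells (Homo sapiens) for antiproliferative activity, read by CCK-8 assay, with a stated time of 72 h, tested at 8 uM; on this read-out higher numbers stand for a stronger effect at the one concentration tested and lower numbers for a weaker effect. Compound 3 `CCCCn1cnc2c(Nc3ccccc3)nc(NCOCc3ccc(C(=O)Nc4ccccc4N)cc3)nc21` stands highest of the three: in this assay compound 3 gives 70.7%. Nearest to it is compound 2 `CC(C)n1cnc2c(Nc3cccc(Cl)c3)nc(NCOCc3ccc(C(=O)Nc4ccccc4N)cc3)nc21`, which in this assay gives 60.5%, a gap beyond the scatter. Furthest is compound 1 `CCCCn1cnc2c(Nc3cccc(Cl)c3)nc(NCOCc3ccc(/C=C/C(=O)Nc4ccccc4N)cc3)nc21`, which in this assay gives 30.4%, again beyond the scatter. No pair among these three differs in a single place, so no step between measured compounds can be read off directly; compound 2 and compound 1 both carry the chloro on the anilino ring that compound 3 lacks, but each also differs from compound 3 elsewhere.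

The next compound, compound 4 `CCCCn1cnc2c(Nc3cccc(Cl)c3)nc(NCOCc3ccc(C(=O)Nc4ccccc4N)cc3)nc21`, differs from compound 3 in one place: chloro in place of hydrogen on an aromatic carbon. Since the two compounds that carry the 3-chlorophenyl, compound 2 and compound 1, both sit below compound 3, a modest fall is expected for this step, near the edge of the scatter rather than a large move; the expected step from compound 3 to compound 4 is a number 10.7 percentage points lower from compound 3 to compound 4 (beyond the scatter). Compound 4 is therefore estimated to give 60% in this assay, expected to fall between 42% and 76%.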

Compound 4, a percentage reported as inhibition, at one concentration (the size of the read-out at that concentration, not a potency): 63.1%
For compound 4 the middle estimate is 3.1 percentage points below the measured one; low and high end bracket the measured number.
By their numbers in this assay, from the lowest: compound 1; then compounds 2, 4 and 3 (each within the scatter of the next, the first and the last beyond it).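

In this assay, among the compounds shown here, the change from phenyl to 3-chlorophenyl reads as a number 7.6 percentage points lower from compound 3 to compound 4 (within the scatter) and so gives no change that can be told from the scatter, which the earlier compounds could not show with no pair among them differing in one place. For the compounds shown here, the same holds on the aromatic nitrogen, where butyl in place of isopropyl reads as a number 2.6 percentage points higher from compound 2 to compound 4 (within the scatter) and these two groups cannot be told apart here, while the one large single-place change is (2-aminophenyl)carbamoyl in place of 2-((2-aminophenyl)carbamoyl)ethenyl, read as a number 32.7 percentage points higher from compound 1 to compound 4 (beyond the scatter) with the 3-chlorophenyl and butyl groups held fixed. Nothing measured here speaks to the reason for any of these steps.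

Still open, going by these compounds, is whether a fluoro, a methyl or a methoxy in place of the chloro on the anilino ring would stay as close to hydrogen, and whether a longer chain such as hexyl or a cyclopentyl on the aromatic nitrogen would stay as close to butyl. Also open, on these data alone, is whether the large step tied to the ethenyl group would recur with a plain phenyl or an isopropyl elsewhere in the molecule.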